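The compounds below may be only part of what the source reports. "The series", "measured", "known", "first", "only" and "open" are said of these compounds alone.

The study measured two compounds in an ADME assay on RAW264.7 cells (Mus musculus) for cytotoxicity, read by MTT assay, with a stated time of 48 h; a lower number here means that less compound is tolerated, a higher number that more compound is tolerated. Compound 1, whose structure is `CC(=O)OC[C@H]1O[C@H](OC[C@@H](Cn2cc(CN(c3nc(-c4cccc([N+](=O)[O-])c4)no3)C3CCCCC3)nn2)OC(C)=O)C=C[C@@H]1OC(C)=O`, gives in this assay a value of 100 ug/mL, the higher of the two numbers. Compound 2, with structure `C#Cc1ccc(-c2noc(NC3CCCCC3)n2)cc1`, gives in this assay 19.8 ug/mL, which lies beyond the usual scatter below the number of compound 1, so compound 1 is the better tolerated of the pair.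

Compound 3, with structure `CC(=O)OC[C@H]1O[C@H](OC[C@@H](Cn2cc(CN(c3nc(-c4ccc(F)cc4)no3)C3CCCCC3)nn2)OC(C)=O)C=C[C@@H]1OC(C)=O`, has not yet been tested in this assay. It differs from compound 1 in one place: 4-fluorophenyl in place of 3-nitrophenyl on an aromatic carbon. Among the compounds with values here, no measured pair of compounds shows this change, so its effect in this assay is not known from the data. Since compound 1 already gives 100 ug/mL, the step from compound 1 to compound 3 is expected to be small, within the scatter, as a 1.2-fold lower number from compound 1 to compound 3 (0.07 log units; within the scatter). Compound 3 is therefore estimated at 85 ug/mL, with a range from 40 ug/mL to 150 ug/mL.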

Compound 3, half-maximal cytotoxic concentration: 31.5 ug/mL
Compound 3: middle estimate off by 2.7-fold (0.43 log units), on the high side, and the stated range ends above it.
By their numbers in this assay, from the lowest: compounds 2 and 3 (each within the scatter of the next); then compound 1.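

In this assay the group on the aromatic carbon of the five-membered aromatic ring proves to matter: with the rest of the molecule unchanged, 4-fluorophenyl in place of 3-nitrophenyl gives a 3.2-fold lower number from compound 1 to compound 3 (0.50 log units; beyond the scatter) in this single comparison. Within the data shown here, this is the first direct reading at this position, and it shows that the aryl group alone can move the tolerated concentration beyond the scatter, with 3-nitrophenyl on the better tolerated side of this pair. No available evidence accounts for this step.

The change alters both the substituent and its place on the phenyl ring, so the compounds shown do not separate these two differences. Where a plain phenyl or a methoxyphenyl at this position would fall remains open.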